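The source may hold more compounds than are shown below. What is called first, only, known or untested is meant among the compounds shown, and "the series" means these compounds.

Measured compounds:
- Compound 1, `CN/C(=N\CCC(c1ccc(F)cc1)c1ccccn1)NCCCc1c[nH]cn1`: in an assay on cardiac atrium with histamine H2 receptor (Cavia porcellus) as the target (a lower number here means a smaller maximal response, a higher number a larger maximal response), compound 1 gives 1
- Compound 2, `c1ccc(C(CCC/N=C(/NCCCc2c[nH]cn2)NC2CCCCC2)c2ccccn2)cc1`: in this assay compound 2 gives 0.25
- Compound 3, `N=C(NCCCc1c[nH]cn1)NCCC(c1ccc(Br)cc1)c1ccccn1`: in this assay compound 3 gives 1

Compound 1 sits at the top of this small set in this assay. Its value and that of compound 3 agree at the digits shown, a gap that lies within the usual scatter, so no order between them can be read. Compound 2 lies far below both, a gap well beyond the scatter, and is the only one of the three that does not reach the full response of the reference.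

Compound 4, `CN/C(=N\CCC(c1ccc(Br)cc1)c1ccccn1)NCCCc1c[nH]cn1`, has not yet been measured. Within the data shown here, its single difference from compound 1 is bromo in place of fluoro on an aromatic carbon. The same bromo group is already present in compound 3, which reaches the full response, and compound 1 carries the fluoro group and also reaches it. Among the measured compounds shown here, nothing among the measured compounds points to the swap changing the maximal response.

The step of no change at the digits printed from compound 1 to compound 4 (within the scatter) is therefore expected to be no change beyond the scatter. The estimate for compound 4 in this assay is 1, with a range from 0.85 to 1.05.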

Compound 4, intrinsic activity: the largest response reached, as a fraction of the reference agonist's: 0.9
Compound 4: the middle estimate sits 0.10 above what was measured; the measured number falls inside the stated range.
By their numbers in this assay, from the lowest: compound 2; then compounds 4, 1 and 3 (each within the scatter of the next).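

Putting bromo in place of fluoro on an aromatic carbon, para to a large group, gives in this assay a step of a number 0.10 lower from compound 1 to compound 4 (within the scatter). Among these compounds, this is the first direct comparison of the two halogens on one and the same core, since the earlier compounds carried fluoro and bromo on different cores and so could not isolate this change. At this position, the change from 4-fluorophenyl to 4-bromophenyl therefore leaves no readable difference in maximal response, and nothing available here bears on why the response holds.

Fluoro and bromo are the only two groups compared at this position, so it remains open whether a methoxy group, a nitrile, an amine or a carboxylic acid there would keep the same maximal response. As far as these compounds go, it is also open whether the same swap would leave the response equally unchanged on a core like that of compound 2, which gives 0.25 in this assay and so has a much smaller maximal response to start from.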